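Ester chain extension on the pyridin-4-yl dihydropyridine core

This account rests on a few compounds, and the source may have more. Where it says the series, first, only, none or still open, it means among the compounds named here.

Measured compounds:
compound 1 `CCO/C(O)=C1\C(C)=NC(C)=C([N+](=O)[O-])C1c1ccncc1`: 6460 nM
compound 2 `CC1=NC(C)=C([N+](=O)[O-])C(c2ccccn2)/C1=C(\O)OCC(C)C`: 9100 nM
compound 3 `CCO/C(O)=C1\C(C)=NC(C)=C([N+](=O)[O-])C1c1ccccn1`: 22800 nM

In a functional assay (cardiac atrium) for agonist activity, with Cavia porcellus as the target (on this read-out lower numbers stand for an effect already at smaller amounts and higher numbers for an effect only at larger amounts of compound), compound 1 gives 6460 nM. Compound 2 sits within the scatter of compound 1, while compound 3 gives a number beyond the scatter above it: a 3.5-fold higher number from compound 1 to compound 3 (0.55 log units; beyond the scatter). Compound 1 thus stands at the favourable end of the three numbers, though not separable from compound 2.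

Compound 4 `CC1=NC(C)=C([N+](=O)[O-])C(c2ccncc2)/C1=C(\O)OC(C)C` differs from compound 1 by one change: methyl in place of hydrogen on a saturated chain carbon bound to an oxygen on an unsaturated carbon and a saturated chain carbon.

Among the compounds with values here, one measured step bears on this change. The step of a 2.5-fold higher number from compound 2 to compound 3 (0.40 log units; beyond the scatter) is the same kind of difference on the same saturated chain carbon, read in the opposite direction; there the shorter chain gave the higher number, so going from the shorter to the longer chain in compound 4 should give a lower number in this assay. That step was modest, and the added group here is smaller than in compound 2, so a step of about the same size or slightly less is expected: a 1.7-fold lower number from compound 1 to compound 4 (0.23 log units; within the scatter). Within the data shown here, only one step informs this, on a differently placed pyridinyl, so the range is kept wide.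

Compound 4 is expected to give 3800 nM, with a range from 1700 nM to 8500 nM.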

Compound 4, half-maximal effective concentration: 8050 nM
The estimate for compound 4 lay 2.1-fold (0.33 log units) below the measured number, within the range that was stated.
By their numbers in this assay, from the lowest: compounds 1, 4 and 2 (each within the scatter of the next); then compound 3.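

In this assay, adding methyl on the saturated chain carbon bound to the oxygen, ethoxy to isopropoxy, gives a 1.2-fold higher number from compound 1 to compound 4 (0.10 log units; within the scatter), so compound 1 and compound 4 cannot be told apart and this branching shows no effect on the pyridin-4-yl compounds. Within the data shown here, the only earlier chain step, a 2.5-fold higher number from compound 2 to compound 3 (0.40 log units; beyond the scatter), lay beyond the scatter, but it involved a different chain on the pyridin-2-yl compounds, so its direction does not extend to this change, and these compounds cannot show whether the ring placement or the chain difference separates the two results. No supporting data bear on why this branching leaves the number within the scatter.

As far as these compounds go, it remains open what the chain of compound 2 would give on the pyridin-4-yl compounds, which would show directly whether the chain step depends on the pyridinyl placement. Also open, from the compounds shown here alone, are a tert-butyl group or a longer straight chain such as n-hexyl at this oxygen, and whether any of these would move the number beyond the scatter from compound 1.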